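Swapping a methylphenyl for a dichlorophenyl on the quinoline carboxamide

The source may report more compounds than this note shows. Statements on the series, on what has been measured and on what is new or still open speak of the compounds shown alone.

Compound 1: `COc1cc2c(Oc3ccc(NC(=O)c4cc(-c5cccc(Cl)c5)nc5ccccc45)cc3F)ccnc2cc1OCCCN1CCCCC1` gives 150 nM in a functional assay on U-87MG ATCC cells (Homo sapiens) for cytotoxicity, read by MTT assay, with a stated time of 72 h; a higher number here means a weaker inhibitor, a lower number a stronger inhibitor.
Compound 2: `COc1cc2c(Oc3ccc(NC(=O)c4cc(-c5ccccc5)nc5ccc(F)cc45)cc3F)ccnc2cc1OCCCN1CCCCC1` gives 690 nM in this assay.
Compound 3: `COc1cc2c(Oc3ccc(NC(=O)c4cc(-c5ccc(C)cc5)nc5ccc(F)cc45)cc3F)ccnc2cc1OCCCN1CCCCC1` gives 1050 nM in this assay.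

Compound 3 has the highest number of the three in this assay. Compound 2 sits closest to it, and the two are within the usual scatter of each other, so no order between them can be claimed. Compound 1 sits furthest away, with a number clearly lower than that of compound 3, but compound 1 differs from compound 3 in two places at once, so its value cannot be tied to a single change.

Compound 4 is `COc1cc2c(Oc3ccc(NC(=O)c4cc(-c5ccc(Cl)cc5Cl)nc5ccc(F)cc45)cc3F)ccnc2cc1OCCCN1CCCCC1`. It differs from compound 3 in one place: 2,4-dichlorophenyl in place of 4-methylphenyl on an aromatic carbon. Among the compounds with values here, the only single step measured on this same position is a 1.5-fold higher number from compound 2 to compound 3 (0.18 log units; within the scatter), a change too small to stand out from the scatter. Within the data shown here, no measured step puts a chlorine on this ring alone, so the size of the coming step is uncertain. On the shared core, compound 4 is expected to move by a 2.1-fold lower number from compound 3 to compound 4 (0.32 log units; beyond the scatter) in this assay, a modest shift toward a lower number that may not clear the scatter. Compound 4 is therefore estimated at 500 nM, with a plausible range from 150 nM to 1700 nM.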

Compound 4, half-maximal inhibitory concentration: 1040 nM
Compound 4: the middle estimate sits 2.1-fold (0.32 log units) below what was measured; the range from low to high includes it.
By their numbers in this assay, from the lowest: compound 1; then compounds 2, 4 and 3 (each within the scatter of the next).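

On the shared core, the aromatic carbon next to the ring nitrogen now carries 2,4-dichlorophenyl, and in this assay putting this group in place of 4-methylphenyl shows no change beyond the scatter (a 1.0-fold lower number from compound 3 to compound 4 (0.00 log units; within the scatter)). Within the data shown here, the comparison with the plain phenyl of compound 2 reads the same way (a 1.5-fold higher number from compound 2 to compound 4 (0.18 log units; within the scatter)), so phenyl, 4-methylphenyl and 2,4-dichlorophenyl at this carbon cannot be told apart in this assay, a wider statement than the single methyl step could support. No measurement shown here offers an explanation for this result.

The compounds shown leave open what sets compound 1 apart at 150 nM, as it differs from the others in two places at once and its value cannot be tied to either one alone. Also open, going by these compounds, is whether an amine or a carboxylic acid on this phenyl ring, or a longer chain at this same carbon in place of the ring, would move the number in this assay beyond the scatter.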